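A few compounds are considered here, and "the series" means these few. Any claim that something is new, unique, unknown or untested is made for them only; others in the source may bear on it.

Measured so far in a functional assay on the whole organism (strain albino) for inhibition, with Rattus norvegicus as the target, read by paw edema, with stated times of 30 min and 3 h, at a dose of 25 mg/kg by the intraperitoneal route; on this read-out higher numbers stand for more inhibition at the one dose given (going by the name of the read-out) and lower numbers for less inhibition:

Compound 1 `CCOC(=O)c1nn(-c2ccccc2)c(-c2ccc(OC)cc2OC)c1-c1ccccc1` gives 20.8% in this assay.
Compound 2 `CCOC(=O)c1nn(-c2ccccc2)c(-c2ccc(OC)cc2OC)c1C` gives 5.81% in this assay.
Compound 3 `COc1ccc(-c2c(C)c(C(=O)O)nn2-c2ccc(Cl)cc2)c(OC)c1` gives 22.8% in this assay.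

Compounds 1 and 2 share a core and differ in one place: phenyl in place of methyl on an aromatic carbon. That change gives a number 15 percentage points higher from compound 2 to compound 1 (beyond the scatter). Compound 3 carries a different core; the difference between the two cores is not broken down here. Compound 3 stands highest of the three numbers, though its gap to compound 1 is within the scatter, so no order between those two is claimed.

Compound 4 `COc1ccc(-c2c(-c3ccccc3)c(C(=O)O)nn2-c2ccc(Cl)cc2)c(OC)c1` is not yet measured. It relates to compound 3 by phenyl in place of methyl on an aromatic carbon. This is the same kind of change as that from compound 2 to compound 1, but the surroundings differ: in compound 3 the place is next to the ring atom that bears a carboxy group and two ring bonds from the ring atom that bears a 4-chlorophenyl group, whereas in compound 2 it is next to the ring atom that bears an ethoxycarbonyl group and two ring bonds from the ring atom that bears a phenyl group.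

The step expected from compound 3 to compound 4 is a number 12.2 percentage points higher from compound 3 to compound 4 (beyond the scatter), set beside the earlier one because of a number 15 percentage points higher from compound 2 to compound 1 (beyond the scatter) and widened for the changed surroundings. Compound 4 is therefore estimated at 35%, between 22% and 50%.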

Compound 4, a percentage reported as inhibition, in the whole organism at one dose (the size of the read-out at that dose, not a potency): 45.5%
Compound 4: the middle estimate sits 10.5 percentage points below what was measured; the measured number falls inside the stated range.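

In this assay, phenyl in place of methyl on an aromatic carbon gives a number 22.7 percentage points higher from compound 3 to compound 4 (beyond the scatter), so the same change raises the number on this core as well. Set beside the earlier step, its size carries from one core to the other as far as the scatter allows: the same change on two cores in this assay, a number 15 percentage points higher (beyond the scatter) from compound 2 to compound 1 and a number 22.7 percentage points higher (beyond the scatter) from compound 3 to compound 4, 7.7 percentage points apart, within the scatter of two such steps

This rests on two pairs at a single dose, so it supports the transfer between these two cores only; it shows nothing about other cores or about potency, and it gives no reason for the rise.

What an ethyl chain, a cyclohexyl ring or a phenyl bearing an amine would give at this place remains open, so the compounds shown cannot say whether the rise is specific to an unsubstituted phenyl. Also open is how a carboxy group compares with an ethoxycarbonyl group, and a 4-chlorophenyl group with a phenyl group, since no pair shown differs in only one of these places.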